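Swapping the Sulfonyl Aryl Group: Clearance Outlook

The source may hold more compounds than are shown below. What is called first, only, known or untested is meant among the compounds shown, and "the series" means these compounds.

Of the compounds shown here, two sharing one core have been measured in an ADME assay on microsomes from liver (Homo sapiens) for metabolic stability, tested at 2.5 uM; on this read-out higher numbers stand for fast clearance and lower numbers for slow clearance. Compound 1 `O=S(=O)(c1cccc(F)c1)c1cnc2c(F)cccc2c1-c1cccc(Cl)c1` gives 0.56 mL/min. Compound 2 `COc1ccc(-c2c(S(=O)(=O)c3ccc(OC)cc3)cnc3c(F)cccc23)cc1` gives 2.12 mL/min, the higher of the two numbers, and its gap to compound 1 is wide enough to lie beyond the usual scatter of the measurement. Compound 3 `COc1ccc(-c2c(S(=O)(=O)c3cccc(F)c3)cnc3c(F)cccc23)cc1` has not yet been run in this assay. It differs from compound 2 in one place: 3-fluorophenyl in place of 4-methoxyphenyl on a sulfonyl sulfur. The group that enters, 3-fluorophenyl on the sulfonyl sulfur, is the same group that compound 1 carries on its sulfonyl sulfur, while the rest of compound 3 stays as in compound 2. Among the compounds with values here, no measured pair isolates this exact change, so the expectation rests on the two values in hand. Because compound 1 gives 0.56 mL/min and compound 2 gives 2.12 mL/min, compound 3 is expected to land between them, in an estimated step of a 1.8-fold lower number from compound 2 to compound 3 (0.25 log units; within the scatter) toward slower clearance that may not clear the scatter. The estimate for compound 3 in this assay is 1.2 mL/min, with an expected range from 0.6 mL/min to 2.4 mL/min.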

Compound 3, intrinsic clearance in a liver preparation (reported as CLH), per the amount of preparation that the assay uses: 2.48 mL/min
For compound 3 the middle estimate is 2.1-fold (0.32 log units) below the measured one; the whole stated range lies below it.
By their numbers in this assay, from the lowest: compound 1; then compounds 2 and 3 (each within the scatter of the next).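

In this assay, 3-fluorophenyl in place of 4-methoxyphenyl on the sulfonyl sulfur gives a 1.2-fold higher number from compound 2 to compound 3 (0.07 log units; within the scatter), so this pair shows no readable effect of exchanging these two groups at this position, even though the groups differ in their atoms and in hydrogen-bond acceptor count. The one other single change available, 4-methoxyphenyl in place of 3-chlorophenyl on an aromatic carbon with 3-fluorophenyl kept on the sulfonyl sulfur, gives a 4.4-fold higher number from compound 1 to compound 3 (0.65 log units; beyond the scatter), so among these three compounds the only step that clears the scatter is the one at the aromatic carbon, not the one on the sulfonyl sulfur. Nothing shown here gives a measured explanation for either step.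

It remains open whether the sulfonyl sulfur would stay just as quiet with 3-chlorophenyl on the aromatic carbon, since compound 1 is the only compound shown with that group and it has no partner differing at the sulfonyl sulfur. Also open, from the compounds shown here alone, is how this assay would read with a group of a different kind on the sulfonyl sulfur, such as a cyclohexyl ring or a phenyl ring carrying a carboxylic acid.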